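The source may report more compounds than this note shows. Statements on the series, on what has been measured and on what is new or still open speak of the compounds shown alone.

Compound 1 (`Cc1ccc(Cn2c(=O)[nH]c3c(N)nc(C(F)(F)F)cc32)cn1`) reads < 8.5 mL.min-1.g-1 in an in vitro ADME assay on microsomes from liver (Rattus norvegicus) for metabolic stability (a higher number here means faster removal of the compound, a lower number slower removal), which is a limit of the assay and not a number. Compound 2 (`Cc1nc(Cn2c(=O)[nH]c3c(N)nc(C(F)(F)F)cc32)co1`) also stands at a limit, < 10 mL.min-1.g-1. Among the compounds with values here, the only measured step, a step that the two limits leave unreadable from compound 1 to compound 2, has no readable size, and it exchanges 6-methylpyridin-3-yl for 2-methyl-1,3-oxazol-4-yl, so it gives little guidance here.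

Compound 3 (`CN1CCN(c2ccc(Cn3c(=O)[nH]c4c(N)nc(C(F)(F)F)cc43)cn2)CC1`) keeps the core of compound 1 but carries 4-methylpiperazin-1-yl in place of methyl on an aromatic carbon, next to the ring nitrogen: 4-methylpiperazin-1-yl in place of methyl on an aromatic carbon. Within the data shown here, no measured step covers this change. The expectation therefore starts from compound 1 at its limit of < 8.5 mL.min-1.g-1 and is loosely judged from the size of the incoming group. The step expected in this assay is upward and modest: an at least 1.6-fold higher number from compound 1 to compound 3 (0.21 log units; that floor lies within the scatter). For compound 3 the estimated value is 14 mL.min-1.g-1, with an expected range of 8 mL.min-1.g-1 to 30 mL.min-1.g-1.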

Compound 3, intrinsic clearance in microsomes: 46 mL.min-1.g-1
Estimate against measurement, compound 3: 3.3-fold (0.52 log units) below, outside the stated range (above it).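

In this assay, within the data shown here, 4-methylpiperazin-1-yl in place of methyl on an aromatic carbon next to the ring nitrogen gives an at least 5.4-fold higher number from compound 1 to compound 3 (0.73 log units; beyond the scatter), the first readable step. Among these compounds, this position therefore responds to the group placed on it, whereas the only earlier step, between two limits, could not be read. The size of the step is a floor only, because compound 1 stands at a limit: the limit of < 8.5 mL.min-1.g-1 in this assay, at which 1 of the 3 values shown sits.

Whether the rise follows from the whole 4-methylpiperazin-1-yl group or from one part of it stays open, as nothing between methyl and that group is shown. A morpholin-4-yl group, a piperazin-1-yl group without its methyl, or a dimethylamino group on the same carbon would separate the ring from its second nitrogen and from the terminal methyl.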